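Succinimide-Bearing Arylpiperazine Amides in a Seizure Model

The compounds below may be only part of what the source reports. "The series", "measured", "known", "first", "only" and "open" are said of these compounds alone.

Measured compounds:
compound 1, `CC(C(=O)N1CCN(c2ccccc2F)CC1)N1C(=O)CCC1=O`, 50%
compound 2, `CC(C(=O)N1CCN(c2ccc(C(F)(F)F)cc2)CC1)N1C(=O)CCC1=O`, 25%
compound 3, `CCC(C(=O)N1CCN(c2ccc(F)cc2)CC1)N1C(=O)CCC1=O`, 25%

The series was examined in a functional assay on the whole organism (strain Swiss) with Mus musculus as the target, in the maximal electroshock model, with a stated time of 0.5 h, at a dose of 300 mg/kg by the intraperitoneal route; on this read-out lower numbers stand for a weaker effect and higher numbers for a stronger effect at the one dose given. Compound 1 gives 50%, compound 2 gives 25% and compound 3 gives 25%. Compound 3 is level with compound 2 at the digits reported, the two together standing at the lowest value of the three, while compound 1 stands higher by a margin that exceeds the usual scatter. No two of the measured compounds differ in one place only, so no single structural step can be read from them directly.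

The piece now turns to compound 4, `CC(C(=O)N1CCN(c2ccc(F)cc2)CC1)N1C(=O)CCC1=O`, which has not yet been measured. It differs from compound 3 in one respect: hydrogen in place of methyl on a saturated chain carbon, two bonds along the chain from an amide-type nitrogen in a ring and a carbonyl carbon. Going by the values given here, no measured pair tells what this change does on its own. The author therefore expects the step from compound 3 to compound 4 to be small and, if anything, upward: a number 10 percentage points higher from compound 3 to compound 4 (within the scatter) in this assay, a movement that could well fall within the scatter. For compound 4 the estimate in this assay is 35%, with a plausible range from 10% to 60%.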

Compound 4, a percentage reported as activity, at one dose (the size of the read-out at that dose, not a potency): 50%
Beside the measured number, compound 4's estimate is 15 percentage points below it; the measured number falls inside the stated range.
By their numbers in this assay, from the lowest: compounds 2 and 3 (each within the scatter of the next); then compounds 1 and 4 (each within the scatter of the next).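

In this assay the chain carbon proves to matter in the 4-fluorophenyl compounds: hydrogen in place of methyl, which reads as ethyl to methyl one bond further out, gives a number 25 percentage points higher from compound 3 to compound 4 (beyond the scatter) and so separates two compounds otherwise alike. With the methyl form in place, fluoro in place of trifluoromethyl on an aromatic carbon gives a number 25 percentage points higher from compound 2 to compound 4 (beyond the scatter) and shows that the aromatic substituent also counts. Moving to 4-fluorophenyl in place of 2-fluorophenyl on an amine nitrogen in a ring gives no change at the digits printed from compound 1 to compound 4 (within the scatter) and so does not separate those two compounds.

On these data alone, how a propyl chain on the same carbon, or a chloro group on the aromatic carbon, would read in this assay remains open. Nothing shown gives a reason for any of these steps.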